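The source may report more compounds than this note shows. Statements on the series, on what has been measured and on what is new or still open speak of the compounds shown alone.

Three compounds share one core and differ only in the group on the pendant benzene ring. Compound 1 `Cn1c(-c2ccc([N+](=O)[O-])cc2)nc2cc(C(F)(F)F)ccc21` carries a nitro group there; in an ADME assay on MDBK cells (Bos taurus) for cytotoxicity, read by MTT assay, with a stated time of 96 h (on this read-out higher numbers stand for lower toxicity in this test and lower numbers for higher toxicity in this test), compound 1 gives the limit > 100000 nM, so the assay reports no number for it (the limit of > 100000 nM in this assay, at which 1 of the 3 values shown sits). Compound 2 `Cn1c(-c2ccc(NC(=O)CN3CCCC3)cc2)nc2cc(C(F)(F)F)ccc21` bears the (((pyrrolidin-1-yl)methyl)carbonyl)amino group instead and in this assay gives 65000 nM. Compound 3 `Cn1c(-c2ccc(N)cc2)nc2cc(C(F)(F)F)ccc21`, with a plain amino group, gives 74000 nM in this assay. The measured steps are all small: an at least 1.5-fold lower number from compound 1 to compound 2 (0.18 log units; that floor lies within the scatter) and an at least 1.3-fold lower number from compound 1 to compound 3 (0.13 log units; that floor lies within the scatter) are floors set by the limit, and a 1.1-fold higher number from compound 2 to compound 3 (0.06 log units; within the scatter) lies within the scatter. Of the two real numbers, compound 2 has the lower one, yet its distance to compound 3 is within the scatter, so the two cannot be told apart.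

Compound 4 `Cn1c(-c2ccc(NC(=O)CN3CCN(c4ccccc4)CC3)cc2)nc2cc(C(F)(F)F)ccc21` is not yet measured. It differs from compound 2 in one place: 4-phenylpiperazin-1-yl in place of pyrrolidin-1-yl on a saturated chain carbon bound to a carbonyl carbon. Going by the values given here, no measured step touches this part of the molecule; the steps from compound 1 concern the replacement of nitro, and the step between compound 2 and compound 3 removes the whole acyl chain without moving the number beyond the scatter. The expected step is therefore a 1.3-fold lower number from compound 2 to compound 4 (0.11 log units; within the scatter), nothing beyond the scatter. Compound 4 is expected to give about 50000 nM in this assay, with a range from 20000 nM to 100000 nM.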

Compound 4, half-maximal cytotoxic concentration: 1400 nM
The estimate for compound 4 lay 36-fold (1.55 log units) above the measured number; measured number outside the range, below it.
By their numbers in this assay, from the lowest: compound 4; then compounds 2 and 3 (each within the scatter of the next). At a limit, above all of these: compound 1.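

In this assay, the exchange at this place gives a 46-fold lower number from compound 2 to compound 4 (1.67 log units; beyond the scatter) and, on this read-out, a lower number stands for higher toxicity in this test. The earlier compounds shown here gave no sign of this: removing the whole acyl chain gave only a 1.1-fold higher number from compound 2 to compound 3 (0.06 log units; within the scatter) and so left the picture flat, whereas the group on the saturated chain carbon bound to a carbonyl carbon now proves able to move the number far. The change brings in two features at once, a six-membered non-aromatic ring with 2 hetero atoms in place of the five-membered one and a six-membered aromatic ring of carbon only, and nothing measured here explains why the number fell.

The compounds shown do not separate those two features: a plain piperazin-1-yl group at this place, with no phenyl ring on it, would show how much of the fall belongs to the piperazine ring alone. Also open, on these data alone, is whether a chlorine atom or a methoxy group on that phenyl ring would move the number further in either direction.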